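From 3-fluorophenyl to 3,5-dimethylphenyl on a sulfur

The compounds below may be only part of what the source reports. "The series", "measured", "known", "first", "only" and "open" are said of these compounds alone.

In a functional assay on SMMC-7721 cells (Homo sapiens) for inhibition, read by CCK-8 assay, with a stated time of 72 h, tested at 2 uM (on this read-out lower numbers stand for less inhibition of growth and higher numbers for more inhibition of growth at the one concentration tested), compound 1 (`CCc1ccc(SCc2ccc(/C=C/C(=O)Nc3ccccc3N)cc2)cc1`) gives 13.2% and compound 2 (`Nc1ccccc1NC(=O)c1ccc(CSc2cccc(F)c2)cc1`) gives 18.6% while compound 3 (`COc1ccc(SCc2ccc(C(=O)Nc3ccccc3N)cc2)cc1OC`) gives 20.2% as its reading. Compound 2 therefore stands within the usual scatter of both other compounds, and these numbers support no ranking. The next compound to be tested is compound 4 (`Cc1cc(C)cc(SCc2ccc(C(=O)Nc3ccccc3N)cc2)c1`), which differs from compound 2 by carrying 3,5-dimethylphenyl in place of 3-fluorophenyl on a sulfur. Within the data shown here, no two measured compounds differ in just one place, so the data show no direct precedent for this swap. The expected step (a number 1.4 percentage points higher from compound 2 to compound 4 (within the scatter)) is none beyond the scatter, with no clear direction. Compound 4 is estimated at 20% (expected range 9% to 33%).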

Compound 4, percent growth inhibition at one concentration: 29.1%
Beside the measured number, compound 4's estimate is 9.1 percentage points below it, and the stated range covers the measured number.
By their numbers in this assay, from the lowest: compounds 1, 2, 3 and 4 (each within the scatter of the next, the first and the last beyond it).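

In this assay, among these compounds, the group on the sulfur can shift the reading: 3,5-dimethylphenyl in place of 3-fluorophenyl gives a number 10.5 percentage points higher from compound 2 to compound 4 (beyond the scatter), the first step here between compounds differing in one place. This is still a single modest step, seen with one pair of compounds. Nothing available accounts for the shift.

Going by these compounds, whether both methyl groups are needed remains open. So does what an amine or a carboxylic acid on that phenyl ring, or a longer chain such as propyl, would do to growth inhibition.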